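Swapping the Aryl Group on a Nucleoside Core

A few compounds are considered here, and "the series" means these few. Any claim that something is new, unique, unknown or untested is made for them only; others in the source may bear on it.

Compound 1 `OC[C@H]1OC(n2cnc3c(-c4ccc(Cl)cc4)ncnc32)[C@H](O)[C@@H]1O` holds the lowest number of the three measured: in a functional assay on CCRF-CEM cells (Homo sapiens) for inhibition (on this read-out higher numbers stand for weaker inhibition and lower numbers for stronger inhibition), compound 1 gives 900 nM. Compound 2 `CC(=O)OC[C@H]1O[C@@H](n2cnc3c(-c4ccc(F)cc4)ncnc32)[C@H](OC(C)=O)[C@@H]1OC(C)=O` gives 4000 nM, and compound 3 `CC(=O)OC[C@H]1O[C@@H](n2cnc3c(-c4ccc(Cl)cc4)ncnc32)[C@H](OC(C)=O)[C@@H]1OC(C)=O` gives 4300 nM, both clearly apart from compound 1. For the measured compounds named here, the only measured step that alters the aryl group, a 1.1-fold higher number from compound 2 to compound 3 (0.03 log units; within the scatter), is small. Compound 4 `COc1cccc(-c2ncnc3c2ncn3C2O[C@H](CO)[C@@H](O)[C@H]2O)c1` differs from compound 1 in one place: 3-methoxyphenyl in place of 4-chlorophenyl on an aromatic carbon. Going by the values given here, no measured pair shows a methoxy group entering, so the expectation rests on that single small aryl step together with the value of compound 1. The step of a 1.3-fold higher number from compound 1 to compound 4 (0.12 log units; within the scatter) is therefore expected to stay within the scatter. Compound 4 is estimated at 1200 nM, in a range from 300 nM to 5000 nM.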

Compound 4, half-maximal inhibitory concentration: 4800 nM
Compound 4: middle estimate off by 4.0-fold (0.60 log units), on the low side, within the range that was stated.
By their numbers in this assay, from the lowest: compound 1; then compounds 2, 3 and 4 (each within the scatter of the next).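

In this assay, replacing 4-chlorophenyl with 3-methoxyphenyl on the shared core gives a 5.3-fold higher number from compound 1 to compound 4 (0.73 log units; beyond the scatter), so the aryl group at this position can change the read-out. The earlier chloro-for-fluoro swap on the acetylated compounds, a 1.1-fold higher number from compound 2 to compound 3 (0.03 log units; within the scatter), did not show this. No evidence at hand explains the step.

On these data alone, whether the methoxy group itself or its place on the phenyl ring drives the step stays open, as both differ at once. As far as these compounds go, how an amine or a carboxylic acid on that phenyl ring would behave is also open.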